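The source may hold more compounds than are shown below. What is called first, only, known or untested is meant among the compounds shown, and "the series" means these compounds.

Working notes on the series. In a functional assay on K562 cells (Homo sapiens) for antiproliferative activity, read by MTT assay, with a stated time of 72 h (a higher number here means a weaker inhibitor, a lower number a stronger inhibitor), compound 2, `COc1cc(-c2ncnn2-c2ccccc2)cc(OC)c1OC`, gives > 10000 nM, which is a limit of the assay and not a number. Compound 1, `COc1cc(-c2ncnn2-c2cccc(F)c2)cc(OC)c1OC`, gives > 10000 nM, which is also a limit. The whole record so far is the limit of > 10000 nM in this assay, at which 2 of the 2 values shown sit, so compound 2 has no readable position, only a limit.

The next change leads to compound 3, `COc1cc(-c2ncnn2-c2cccc([N+](=O)[O-])c2)cc(OC)c1OC`, with nitro in place of hydrogen on an aromatic carbon. Within the data shown here, the only measured step that bears on this ring is the exchange of fluoro for hydrogen on an aromatic carbon, and it reads as a step that the two limits leave unreadable from compound 1 to compound 2. No step beyond the scatter is expected in this assay because a step that the two limits leave unreadable from compound 1 to compound 2 supplies no size or direction to carry over. The expected step is a step that the limit leaves unreadable from compound 2 to compound 3, and this is an estimate without a firm direction. Compound 3 is expected to be reported as a limit again, more likely than not. The estimate for compound 3 is 12000 nM, with an expected range from 4000 nM to 30000 nM.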

Compound 3, half-maximal inhibitory concentration: > 10000 nM
Compound 3: no number, only a limit; the forecaster's own chance of this, stated with the estimate: 80%; the middle value lies beyond the limit too.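

Compound 3 gives > 10000 nM in this assay, a limit of the assay and not a number. No step can be read among compound 1, compound 2 and compound 3, because all three stand at the same limit: the limit of > 10000 nM in this assay, at which 3 of the 3 values shown sit.

The compounds shown leave open whether hydrogen, fluoro or nitro on this ring makes any difference in this assay.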